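A few compounds are considered here, and "the series" means these few. Any claim that something is new, unique, unknown or untested is made for them only; others in the source may bear on it.

Measured in a functional assay on A549 cells (Homo sapiens) for inhibition, read by MTT assay, with a stated time of 72 h; on this read-out higher numbers stand for weaker inhibition and lower numbers for stronger inhibition:
- compound 1 `CC1=NN(c2ccccc2)C(=O)[C@@]12C(=O)C=CC[C@@H]2c1cccc(C)c1`: 4510 nM
- compound 2 `CC1=NN(c2ccccc2)C(=O)[C@@]12C(=O)C=CC[C@H]2c1ccccc1`: 3770 nM

Only these two compounds have been measured so far. Compound 2, at 3770 nM, lies within the scatter of compound 1, at 4510 nM, so the numbers do not separate them.

The next compound to be tested in this assay is compound 3 `CC1=NN(c2ccccc2)C(=O)[C@@]12C(=O)C=CC[C@@H]2c1ccccc1`. Its relation to compound 2 is purely one of configuration: the two compounds have the same atoms and bonds and differ only in configuration as drawn: 1 of 2 stereo elements differ; a stereocentre at a saturated ring carbon is drawn S in compound 2 and R in compound 3. The two compounds have the same atoms and bonds, and a stereocentre at a saturated ring carbon is drawn S in compound 2 and R in compound 3.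

Within the data shown here, no measured pair shows what such a change in configuration does, so the expectation is loose. The estimated shift is a 1.5-fold higher number from compound 2 to compound 3 (0.16 log units; within the scatter), a small move toward weaker inhibition that is not expected to go far beyond the scatter, although a larger step cannot be excluded. For compound 3 the estimated value is 5500 nM, with an expected range from 2000 nM to 15000 nM.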

Compound 3, half-maximal inhibitory concentration: 7770 nM
Compound 3: the middle estimate sits 1.4-fold (0.15 log units) below what was measured; the range from low to high includes it.
By their numbers in this assay, from the lowest: compounds 2, 1 and 3 (each within the scatter of the next, the first and the last beyond it).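

In this assay, among these compounds, the stereocentre at a saturated ring carbon provides the first readable comparison of configuration: a 2.1-fold higher number from compound 2 to compound 3 (0.31 log units; beyond the scatter), a modest step that lies just beyond the scatter, with the lower number on the S drawing. This step can be assigned to configuration alone, and to no change of atoms or bonds, because of what separates the pair: the fact that compounds 2 and 3 differ only in the configuration as drawn. Hydrogen in place of methyl on an aromatic carbon gives a 1.7-fold higher number from compound 1 to compound 3 (0.24 log units; within the scatter), so with the stereocentre drawn R, the numbers do not separate the methyl-bearing compound from its counterpart with hydrogen.

The compounds shown leave open what inverting this stereocentre does when the aromatic ring carries the methyl group, and what a change at the second stereocentre would do to the numbers. They also leave open how an amine, a carboxylic acid or a methoxy group on that aromatic ring would compare with hydrogen and methyl in this read-out.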